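The compounds below may be only part of what the source reports. "The series", "measured", "known", "first", "only" and "open" are said of these compounds alone.

Values measured in an ADME assay on BHK-21 cells (Mesocricetus auratus) for cytotoxicity, read by MTT assay, with a stated time of 96 h; a higher number here means that more compound is tolerated, a lower number that less compound is tolerated:

Compound 1 `CN(C)CCCN(/N=N/c1ccc([N+](=O)[O-])cc1)c1ccccc1`: 36000 nM
Compound 2 `Clc1cccc(/N=N/N2CCCCC2)c1`: > 100000 nM (a limit)
Compound 3 `c1ccc(/N=N/N2CCCC2)cc1`: >= 100000 nM (a limit)

Of these three compounds, only compound 1 has a measured number, 36000 nM. Compound 2 stands at a limit of the assay, > 100000 nM, and this is not a number. Compound 3 is likewise reported only as a limit, >= 100000 nM. No two of the measured compounds differ in a single place, so this assay offers no direct measure of what one such change does.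

The next compound, compound 4 `Brc1cccc(/N=N/N2CCCCC2)c1`, has bromo in place of chloro on an aromatic carbon of a six-membered aromatic ring of carbon only, meta to a group of 8 heavy atoms: bromo in place of chloro on an aromatic carbon. Everything else in compound 2 is kept. The expectation rests on this single swap and on compound 2, with its limit of > 100000 nM. No shift beyond the usual scatter is expected, and compound 4 may well be reported only as a limit too. The estimated change is a number no higher from compound 2 to compound 4 (the limit leaves the size open). In this assay the estimate for compound 4 is 100000 nM, with the result expected to fall between 45000 nM and 200000 nM.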

Compound 4, half-maximal cytotoxic concentration: > 100000 nM
Compound 4 gave a limit, no number (the forecaster's own chance of this, stated with the estimate: 70%); the middle value lies on the limit itself.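

Compound 2 and compound 4 are both reported only as limits, so the swap of bromo for chloro gives no readable step between them: the limit of > 100000 nM in this assay, at which 2 of the 4 values shown sit.

The compounds shown leave open how much of compound 2 or compound 4 is tolerated in this assay, and whether bromo in place of chloro on an aromatic carbon changes that at all.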